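Compound 3 to compound 4: a change of aryl group

A few compounds are considered here, and "the series" means these few. Any claim that something is new, unique, unknown or untested is made for them only; others in the source may bear on it.

Going by the values given here, in a functional assay on A549 cells (Homo sapiens) for antiproliferative activity, read by spectrophotometry, with a stated time of 2 days (on this read-out lower numbers stand for stronger inhibition of growth and higher numbers for weaker inhibition of growth), compound 3 `Cc1ccc(Nc2ncc(C(F)(F)F)c(N3Cc4cccc(N(C)S(C)(=O)=O)c4C3)n2)c(C)c1` gives 20700 nM, the only actual number in the set so far. Compound 1 `COc1ccc(C(F)(F)F)cc1Nc1ncc(C(F)(F)F)c(N2Cc3cccc(N(C)S(C)(=O)=O)c3C2)n1` reads > 30000 nM, which is a limit of the assay. Compound 2 `CN(c1cccc2c1CN(c1nc(Nc3cc(C(F)(F)F)cc(C(F)(F)F)c3)ncc1C(F)(F)F)C2)S(C)(=O)=O` reads > 30000 nM, which is also a limit. Most of the set therefore sits at one boundary: the limit of > 30000 nM in this assay, at which 2 of the 3 values shown sit.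

Compound 4 `CN(c1cccc2c1CN(c1nc(Nc3cc(Cl)cc(C(F)(F)F)c3)ncc1C(F)(F)F)C2)S(C)(=O)=O` differs from compound 3 in one place: 3-chloro-5-(trifluoromethyl)phenyl in place of 2,4-dimethylphenyl on a nitrogen on an aromatic ring. Here 3-chloro-5-(trifluoromethyl)phenyl stands in place of 2,4-dimethylphenyl on a nitrogen on an aromatic ring.

Among the compounds with values here, only one measured step bears on this place: an at least 1.4-fold lower number from compound 1 to compound 3 (0.16 log units; that floor lies within the scatter). From the compounds shown here alone, it brings in 2,4-dimethylphenyl in place of 2-methoxy-5-(trifluoromethyl)phenyl, and its true size remains open. Leaving 2,4-dimethylphenyl for another trifluoromethyl-bearing group thus offers no ground for expecting stronger inhibition. No step beyond the scatter is expected in this assay, with any drift more likely toward weaker inhibition, and a reading at the limit is quite possible. The expected change is a 1.4-fold higher number from compound 3 to compound 4 (0.13 log units; within the scatter). For compound 4 the estimate is 28000 nM, with an expected range of 12000 nM to 60000 nM.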

Compound 4, concentration for 50% growth inhibition: 6700 nM
For compound 4 the middle estimate is 4.2-fold (0.62 log units) above the measured one, and the stated range ends above it.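

In this assay, the place on a nitrogen on an aromatic ring now shows a step beyond the scatter, which the earlier step there did not: a 3.1-fold lower number from compound 3 to compound 4 (0.49 log units; beyond the scatter), leaving compound 4 with the lowest number of the four compounds. Trifluoromethyl on this aryl group does not by itself keep the reading at the limit, since compound 4 carries it too; chloro in place of the second trifluoromethyl gives an at least 4.4-fold lower number from compound 2 to compound 4 (0.65 log units; beyond the scatter), and 3-chloro-5-(trifluoromethyl)phenyl in place of 2-methoxy-5-(trifluoromethyl)phenyl gives an at least 4.4-fold lower number from compound 1 to compound 4 (0.65 log units; beyond the scatter). Those last two steps start from values of compound 1 and compound 2 that are limits and not numbers, so their true size stays open: the limit of > 30000 nM in this assay, at which 2 of the 4 values shown sit.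

From the compounds shown here alone, whether chloro alone would carry the step, or needs the trifluoromethyl on the same ring, remains open, as does the effect of a nitrile, an amine or a carboxylic acid on that aryl group. Going by these compounds, the shared core is the same in all four compounds, so what a change there would do to growth inhibition is also open.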